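This account rests on a few compounds, and the source may have more. Where it says the series, first, only, none or still open, it means among the compounds named here.

Measured compounds in a functional assay on HCT-116 cells (Homo sapiens) for inhibition, read by MTT assay, with a stated time of 48 h; on this read-out lower numbers stand for stronger inhibition and higher numbers for weaker inhibition:
- compound 1, `COc1ccc(CN(C(=O)CCCl)c2cc(OC)c(OC)c(OC)c2)cc1O`: 150 nM
- compound 2, `C/C=C/C(=O)N(Cc1ccc(OC)c(Br)c1)c1cc(OC)c(OC)c(OC)c1`: 2800 nM
- compound 3, `COc1ccc(N(Cc2cc(OC)c(OC)c(OC)c2)C(=O)CCl)cc1O`: 22500 nM

Compound 1 gives the lowest number of the three in this assay. Compound 2 stands nearest to it, with a higher number that is beyond the scatter, and compound 3 stands furthest, again well beyond the scatter. Within the data shown here, no pair among the measured compounds differs in a single place, so no single-point step can be read from them.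

Compound 4, `COc1ccc(CN(C(=O)CN=[N+]=[N-])c2cc(OC)c(OC)c(OC)c2)cc1O`, is not yet measured in this assay. Compared with compound 1 the change is azido in place of chloromethyl on a saturated chain carbon bound to a carbonyl carbon. The amide substituent is the only part that moves; the shared core and the substituted benzyl group are kept as in compound 1.

Among the measured compounds shown here, with no measured step on this part of the molecule to lean on, the expectation rests on compound 1 alone, whose value 150 nM is the anchor. The step from compound 1 to compound 4 is expected to be small, toward a somewhat higher number, and may not exceed the scatter: a 2.0-fold higher number from compound 1 to compound 4 (0.30 log units; within the scatter). Compound 4 is accordingly estimated at 300 nM, within a range of 60 nM to 1500 nM.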

Compound 4, half-maximal inhibitory concentration: 410 nM
Estimate against measurement, compound 4: 1.4-fold (0.14 log units) below, within the range that was stated.
By their numbers in this assay, from the lowest: compound 1; then compound 4; then compound 2; then compound 3.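

Among these compounds, this is the first single-place step: in this assay, azido in place of chloromethyl on a saturated chain carbon bound to a carbonyl carbon gives a 2.7-fold higher number from compound 1 to compound 4 (0.44 log units; beyond the scatter), a modest change that lies beyond the scatter. Chlorine is thus not needed at this position for a sub-micromolar number, as compound 4, which carries none, gives 410 nM. No measurement at hand bears on the cause of this step.

The change from 2-chloroethyl to azidomethyl alters both the end group and the chain, and the compounds shown do not separate the two. From the compounds shown here alone, how a 2-azidoethyl group, which would keep the chain of compound 1, or an aminomethyl group would stand at this place remains open.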